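The source may report more compounds than this note shows. Statements on the series, on what has been measured and on what is new or still open speak of the compounds shown alone.

Measured so far in a functional assay on SGC-7901 cells (Homo sapiens) for antiproliferative activity, read by MTT assay, with a stated time of 72 h; on this read-out higher numbers stand for weaker inhibition and lower numbers for stronger inhibition:
- compound 1 `COc1cc(-n2cnc3ccc(-c4cccc(O)c4)cc32)cc(OC)c1OC`: 53 nM
- compound 2 `COc1cc(-n2cnc3ccc(-c4cccc(C)c4C)cc32)cc(OC)c1OC`: 3040 nM

Compound 2 holds the higher of the two numbers, at 3040 nM. Compound 3 `COc1cc(-n2cnc3ccc(-c4cccc(N)c4)cc32)cc(OC)c1OC` differs from it as follows: 3-aminophenyl in place of 2,3-dimethylphenyl on an aromatic carbon. Within the data shown here, the only measured step bearing on this is a 57-fold higher number from compound 1 to compound 2 (1.76 log units; beyond the scatter), where 2,3-dimethylphenyl replaced 3-hydroxyphenyl. The entering 3-aminophenyl is the closer match to the 3-hydroxyphenyl of compound 1, at 53 nM, so a large move to a lower number is expected in this assay. The expected change is a 25-fold lower number from compound 2 to compound 3 (1.40 log units; beyond the scatter). Compound 3 is estimated at 120 nM, with an expected range of 30 nM to 600 nM.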

Compound 3, half-maximal inhibitory concentration: 21 nM
Beside the measured number, compound 3's estimate is 5.7-fold (0.76 log units) above it; measured number outside the range, below it.
By their numbers in this assay, from the lowest: compound 3; then compound 1; then compound 2.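

At this position on the shared core, 3-aminophenyl gives a 140-fold lower number from compound 2 to compound 3 (2.16 log units; beyond the scatter) in this assay, so the large loss seen with 2,3-dimethylphenyl is more than recovered. Amino and hydroxy can also be told apart here, with amino in place of hydroxy giving a 2.5-fold lower number from compound 1 to compound 3 (0.40 log units; beyond the scatter), a modest step beyond the scatter. Nothing available accounts for either step.

Compounds 1 and 3 do not show whether a methoxy or acetamido group at the same ring position would hold this level. A 3-methylphenyl group would separate the contributions of the two methyl groups in compound 2.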